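The source may report more compounds than this note shows. Statements on the series, on what has been measured and on what is new or still open speak of the compounds shown alone.

Measured in a functional assay on U-87MG ATCC cells for inhibition, with U-87 MG (Homo sapiens) as the target, read by MTT assay, with a stated time of 48 h; on this read-out lower numbers stand for stronger inhibition and higher numbers for weaker inhibition:
- compound 1 `C(=C/c1nc2ccccn2c1Sc1ccccc1)\c1ccccc1`: 59200 nM
- compound 2 `Cc1ccc(-c2nc3ccc(C)cn3c2Sc2ccccc2)cc1`: 82100 nM

Only these two compounds have been measured so far, and they share the phenylsulfanyl group. Compound 1, at 59200 nM, stands within the scatter of compound 2, at 82100 nM, so neither can be ranked above the other in this assay.

The next compound to be measured is compound 3 `c1ccc(Sc2c(-c3ccsc3)nc3ccccn23)cc1`. It keeps the core of compound 1 and carries thiophen-3-yl in place of 2-phenylethenyl on an aromatic carbon, the change being (thiophen-3-yl in place of 2-phenylethenyl on an aromatic carbon). Within the data shown here, no measured pair of compounds differs in one place only, so the data offer no direct precedent for this swap. The two values in hand do show that compound 2, at 82100 nM, differs from compound 1 in its structure without leaving the scatter. A step beyond the scatter in this assay is therefore not expected, in either direction. The expected result is a 1.1-fold lower number from compound 1 to compound 3 (0.03 log units; within the scatter). For compound 3 the estimated value is 55000 nM, with an expected range from 22000 nM to 130000 nM.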

Compound 3, half-maximal inhibitory concentration: 58600 nM
Compound 3: the middle estimate sits 1.1-fold (0.03 log units) below what was measured; the range from low to high includes it.
By their numbers in this assay, from the lowest: compounds 3, 1 and 2 (each within the scatter of the next).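

Among these compounds, the swap of 2-phenylethenyl for thiophen-3-yl, on the aromatic carbon next to the ring atom that bears a phenylsulfanyl group, is the first change in one place that can be read in this assay, and it gives a 1.0-fold lower number from compound 1 to compound 3 (0.00 log units; within the scatter). At this position, a group with 8 heavy atoms, a six-membered aromatic ring of carbon only and a double bond outside aromatic rings can thus be exchanged for a group with 5 heavy atoms and a five-membered aromatic ring holding sulfur, and the two numbers cannot be told apart. No measurement on hand offers an explanation for this result.

Going by these compounds, both groups compared here end in an aromatic ring, so it remains open whether an amine, a carboxylic acid or a longer saturated chain on this carbon would give a step beyond the scatter. The phenylsulfanyl group is also common to compound 1 and compound 3, which leaves open what a plain hydrogen or a benzyl group in its place would do to the number.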